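A Cyano Group Replaces Hydrogen on the Shared Core

A few compounds are considered here, and "the series" means these few. Any claim that something is new, unique, unknown or untested is made for them only; others in the source may bear on it.

The set shares one core carrying a phenyl group that is varied at a single point. Compound 1 `COc1ccc(-c2cs/c(=N/NC(=O)CSc3nnnn3-c3ccccc3)n2-c2ccccc2)cc1` bears a methoxy group there, but in a functional assay on C6 cells (Rattus norvegicus) for cytotoxicity, read by MTT assay, with a stated time of 24 h (on this read-out higher numbers stand for weaker inhibition and lower numbers for stronger inhibition), compound 1 stands as "not determined" (no result reported), with no reported result. Compound 2 `Cc1ccc(-c2cs/c(=N/NC(=O)CSc3nnnn3-c3ccccc3)n2-c2ccccc2)cc1` carries a methyl group, and in this assay compound 2 gives 14.7 ug/mL. Compound 3 `O=C(CSc1nnnn1-c1ccccc1)N/N=c1/scc(-c2ccccc2)n1-c1ccccc1` carries hydrogen at that point, and in this assay compound 3 gives 8.3 ug/mL. On the numbers shown compound 3 stands with the smaller of the two, yet the step of a 1.8-fold lower number from compound 2 to compound 3 (0.25 log units; within the scatter) lies within the scatter, so the two compounds cannot be told apart.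

Compound 4 `N#Cc1ccc(-c2cs/c(=N/NC(=O)CSc3nnnn3-c3ccccc3)n2-c2ccccc2)cc1` is compound 3 with cyano in place of hydrogen on an aromatic carbon: a cyano group of two heavy atoms, carrying one triple bond outside aromatic rings and one hydrogen-bond acceptor, placed on the six-membered aromatic ring of carbon only, para to a large group. For the measured compounds named here, only one measured step bears on substitution at this point, a 1.8-fold lower number from compound 2 to compound 3 (0.25 log units; within the scatter), and it stayed within the scatter. Going by the values given here, no measured step shows a substituent here moving this assay beyond the scatter, so compound 4 is expected to show a step of a 1.1-fold higher number from compound 3 to compound 4 (0.04 log units; within the scatter) that remains within the scatter. The estimate for compound 4 in this assay is 9 ug/mL, with a range from 4.5 ug/mL to 20 ug/mL.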

Compound 4, half-maximal inhibitory concentration: > 200 ug/mL
Compound 4 was reported as a limit; the forecaster's own chance of this, stated with the estimate: 5%; middle value at least 22-fold (1.34 log units) away from the limit.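

In this assay, compound 4 is reported only as a limit, not as a number: the limit of > 200 ug/mL in this assay, at which 1 of the 4 values shown sits. Even so, the step can be read in one direction, since cyano in place of hydrogen gives an at least 24-fold higher number from compound 3 to compound 4 (1.38 log units; beyond the scatter), and cyano in place of methyl gives an at least 13-fold higher number from compound 2 to compound 4 (1.13 log units; beyond the scatter). For the compounds shown here, the earlier compounds, with methyl and hydrogen at this point, could not be told apart, so the change from phenyl to 4-cyanophenyl is the first to show that this position can move the read-out beyond the scatter, and it moves it towards weaker inhibition.

With a single cyano example, and with the methoxy group of compound 1 standing without a result, the compounds shown do not tell whether this large step belongs to cyano alone or would also follow from other groups at this point, such as a chlorine atom, an amine or a carboxylic acid. They also leave open whether moving the nitrile further out on a longer chain would give a step of similar size.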